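The source may report more compounds than this note shows. Statements on the series, on what has been measured and on what is new or still open speak of the compounds shown alone.

Measured compounds:
- Compound 1, `CCn1c(-c2ccccc2)nc2c(NC3CCOC3)ncnc21`: 1660 nM
- Compound 2, `Cn1c(-c2ccccc2)nc2c(NC3CCCC3)ncnc21`: 846 nM

Both were tested in an assay on CHO cells for displacement of a labelled ligand from adenosine receptor A3 (Homo sapiens), read by scintillation counting, with a stated time of 3 h; a lower number here means a stronger inhibitor, a higher number a weaker inhibitor. Compound 2 gives 846 nM there, and compound 1 gives 1660 nM; the gap between the two lies within the usual scatter of this assay, so compound 2 cannot be set apart from compound 1 on these numbers. Within the data shown here, the two also differ in two places at once, so they carry no single step that can be read on its own.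

Compound 3, `CCn1c(-c2ccccc2)nc2c(NC3CCCC3)ncnc21`, has not yet been measured. It differs from compound 2 in one place: methyl in place of hydrogen on a saturated chain carbon bound to an aromatic nitrogen. The same change, viewed one bond further out, is methyl to ethyl. Compound 1 already carries the ethyl, and its value sits within the scatter of compound 2, which gives no sign that this change moves the number far in either direction. Compound 3 is therefore expected to stay close to compound 2, with an estimated step of a 1.1-fold higher number from compound 2 to compound 3 (0.05 log units; within the scatter) that need not exceed the scatter. The estimate for compound 3 in this assay is 950 nM, between 350 nM and 2600 nM.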

Compound 3, inhibition constant: 354 nM
Compound 3: the middle estimate sits 2.7-fold (0.43 log units) above what was measured; low and high end bracket the measured number.
By their numbers in this assay, from the lowest: compound 3; then compounds 2 and 1 (each within the scatter of the next).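

In this assay, lengthening the group on the aromatic nitrogen from methyl to ethyl gives a 2.4-fold lower number from compound 2 to compound 3 (0.38 log units; beyond the scatter) and so shows that this position responds to that change, something compound 1 and compound 2 could not show, as they differ in two places at once. Compound 3 also gives the first comparison in one place for the group on the nitrogen on an aromatic ring, where cyclopentyl in place of oxolan-3-yl gives a 4.7-fold lower number from compound 1 to compound 3 (0.67 log units; beyond the scatter) and compound 3 is left with the lowest number of those shown. The compounds shown offer no independent measurement that accounts for either step.

On these data alone, whether a longer chain such as propyl, or a small ring such as cyclopropyl, on the aromatic nitrogen would lower the number further remains open, and one added carbon is too little to show a trend at this position. As far as these compounds go, the step from oxolan-3-yl to cyclopentyl is also read here only with the ethyl in place, so whether it keeps its size with methyl on the aromatic nitrogen remains unknown.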